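The compounds below may be only part of what the source reports. "The series", "measured", "known", "first", "only" and "open" are said of these compounds alone.

Measured compounds:

Compound 1 `COc1cccc(-c2cc3[nH]nc(N)c3c(=O)[nH]2)c1`: 2%
Compound 2 `Cc1cc2[nH]nc(N)c2c(N2CCCCC2)n1`: 11%
Compound 3 `Cc1cc2c(c(N)nn2C)c(N2CCCCC2)n1`: 0%

All three numbers come from an assay on isolated protein for inhibition of RAC-beta serine/threonine-protein kinase (Homo sapiens), read by mobility shift assay, tested at 30 uM (on this read-out higher numbers stand for more inhibition at the one concentration tested (going by the name of the read-out) and lower numbers for less inhibition), so each value tells how much of the protein's activity was blocked at a single concentration. Compound 3 has the lowest number of the three. Its nearest neighbour is compound 1, whose value sits within the scatter of repeated measurements, so the two cannot be told apart. Among the measured compounds shown here, its furthest neighbour is compound 2, and that gap is the one measured step in this set: a number 11 percentage points lower from compound 2 to compound 3 (beyond the scatter), a change that comes from putting a methyl group on an aromatic nitrogen of the shared core.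

Compound 4 `Cc1cc2c(c(N)nn2C)c(N2CC[C@H](O)C2)n1` keeps the methylated core of compound 3 and changes only the ring that hangs on the aromatic carbon: 3-hydroxypyrrolidin-1-yl in place of piperidin-1-yl on an aromatic carbon. For the measured compounds named here, no measured step in this set touches that ring, so the single step that was measured does not bear on this change and gives no guidance on direction. With compound 3 already close to no inhibition, the expectation for compound 4 is a step of about a number 3 percentage points higher from compound 3 to compound 4 (within the scatter), which is nothing beyond the scatter. Compound 4 is therefore estimated at 3%, with a range from -8% to 15%.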

Compound 4, a percentage reported as inhibition, at one concentration (the size of the read-out at that concentration, not a potency): 4%
Compound 4: the middle estimate sits 1 percentage points below what was measured; the measured number falls inside the stated range.
By their numbers in this assay, from the lowest: compounds 3, 1, 4 and 2 (each within the scatter of the next, the first and the last beyond it).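

In this assay, among the compounds shown here, the first change at this position, on the aromatic carbon next to the ring nitrogen, replaces piperidin-1-yl with 3-hydroxypyrrolidin-1-yl, and the result is a number 4 percentage points higher from compound 3 to compound 4 (within the scatter). A five-membered ring with a hydroxyl therefore reads the same as the six-membered ring without one, but this says little about the position: compound 3 already stands at 0%, so a swap that weakened inhibition could not show up as a further fall, and neither compound blocks much of the protein at the one concentration tested. Nothing available explains why the two numbers stay together.

The swap changes ring size and adds a hydroxyl in one move, so the compounds shown leave open what each does alone, which plain pyrrolidin-1-yl would begin to separate, and whether other groups here, such as morpholin-4-yl or an open-chain amine, would lift the number clear of the scatter. From the compounds shown here alone, it is also open whether 3-hydroxypyrrolidin-1-yl would behave the same on the core of compound 2, which has hydrogen rather than methyl on the aromatic nitrogen.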